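The compounds below may be only part of what the source reports. "The series", "measured", "known", "first", "only" and "open" are said of these compounds alone.

Compound 1, `CCCCCCCCCCCNC[C@@H]1OC[C@H](N)[C@H]1O`, is one of three close relatives tested in a functional assay on B16-F10 cells (Mus musculus) for antiproliferative activity, read by MTT assay, with a stated time of 72 h; on this read-out lower numbers stand for stronger inhibition and higher numbers for weaker inhibition. In this assay compound 1 gives 88800 nM, the highest number of the three. Compound 2, `CCCCCCCCCCNC[C@@H]1OC[C@H](N)[C@@H]1O`, gives 29600 nM in this assay, and compound 3, `CCCCCCCCCCCNC[C@@H]1OC[C@H](N)[C@@H]1O`, gives 19300 nM. The move from compound 1 to compound 3 is a 4.6-fold lower number from compound 1 to compound 3 (0.66 log units; beyond the scatter), which rests on (the fact that compounds 1 and 3 differ only in the configuration as drawn). The move from compound 2 to compound 3 is a 1.5-fold lower number from compound 2 to compound 3 (0.19 log units; within the scatter), a lengthening of the chain by one carbon that stays inside the ordinary spread of repeat tests.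

Compound 4, `CCCCCCCCCNC[C@@H]1OC[C@H](N)[C@H]1O`, differs from compound 1 by hydrogen in place of ethyl on a saturated chain carbon, nine bonds along the chain from an amine nitrogen. This shortens the chain by two carbons while keeping the core and its drawn configuration unchanged. Going by the values given here, the only measured step that touches chain length, from compound 2 to compound 3, was too small to count, so at most a small rise in the number is expected in this assay from the shorter chain. Compound 4 is therefore expected to give about 150000 nM, somewhere between 60000 nM and 400000 nM, which means an expected step of a 1.7-fold higher number from compound 1 to compound 4 (0.23 log units; within the scatter).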

Compound 4, half-maximal inhibitory concentration: > 128000 nM
Compound 4 gave a limit, no number; the forecaster's own chance of this, stated with the estimate: 20%; the middle value lies beyond the limit too.
By their numbers in this assay, from the lowest: compounds 3 and 2 (each within the scatter of the next); then compound 1. At a limit, above all of these: compound 4.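

Compound 4 is reported in this assay only as a limit, > 128000 nM. This gives an at least 1.4-fold higher number from compound 1 to compound 4 (0.15 log units; that floor lies within the scatter), the first chain-shortening step shown on the drawn configuration of compound 1; the earlier chain step, a 1.5-fold lower number from compound 2 to compound 3 (0.19 log units; within the scatter), was on the other configuration. Hydrogen in place of ethyl at this place brings no fall in the number, but the size of any rise cannot be read, and the step's floor alone does not establish a real loss: the limit of > 128000 nM in this assay, at which 1 of the 4 values shown sits.

On these data alone, the true value of compound 4 remains open, so the chain-length trend on this configuration has only one measured end. Also open is whether a longer chain on the core of compound 1 would lower the number, and whether it would narrow the gap shown by a 4.6-fold lower number from compound 1 to compound 3 (0.66 log units; beyond the scatter).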